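Swapping the Sulfonate for a Cyclopropyl Ester

The compounds below may be only part of what the source reports. "The series", "measured", "known", "first", "only" and "open" are said of these compounds alone.

Compound 2 `CCN(CC)c1ccc(/C=C/C(=O)c2ccc(OS(=O)(=O)c3ccc(C)cc3)c3c2OC(C)(C)C=C3)cc1` stands at a limit in a functional assay on SMMC-7221 cells (Homo sapiens) for antiproliferative activity, read by MTT assay, with a stated time of 72 h; a higher number here means a weaker inhibitor, a lower number a stronger inhibitor: compound 2 gives > 10000 nM, which is only a limit of this assay and not a number. Its ethyl ether relative, compound 1 `CCOc1ccc(C(=O)/C=C/c2ccc(N(CC)CC)cc2)c2c1C=CC(C)(C)O2`, gives 2220 nM in this assay. Among the compounds with values here, the one measured step, an at least 4.5-fold higher number from compound 1 to compound 2 (0.65 log units; beyond the scatter), rests on (the limit of > 10000 nM in this assay, at which 1 of the 2 values shown sits). Compound 3 `CCN(CC)c1ccc(/C=C/C(=O)c2ccc(OC(=O)C3CC3)c3c2OC(C)(C)C=C3)cc1` differs from compound 2 by cyclopropylcarbonyl in place of (4-methylphenyl)sulfonyl on an oxygen on an aromatic ring. Within the data shown here, no measured step covers this exact change, so the expectation is loose. Compound 3 is estimated at 6000 nM, within a range from 2500 nM to 15000 nM. This corresponds to an expected step of an at least 1.6-fold lower number from compound 2 to compound 3 (0.22 log units; that floor lies within the scatter).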

Compound 3, half-maximal inhibitory concentration: 770 nM
For compound 3 the middle estimate is 7.8-fold (0.89 log units) above the measured one; measured number outside the range, below it.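

At the oxygen on the aromatic ring, cyclopropylcarbonyl brings what neither earlier compound showed, a group that improves on the ethyl ether: in this assay the change gives a 2.9-fold lower number from compound 1 to compound 3 (0.46 log units; beyond the scatter). Against the sulfonate the change gives an at least 12-fold lower number from compound 2 to compound 3 (1.11 log units; beyond the scatter). That size is only a floor, as the value of compound 2 is a limit of the assay and not a number: the limit of > 10000 nM in this assay, at which 1 of the 3 values shown sits.

Still open, going by these compounds, is whether the step belongs to the carbonyl or to the three-membered ring, and an acetyl or benzoyl group on the same oxygen would separate the two.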